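The compounds below may be only part of what the source reports. "The series", "measured", "known", "first", "only" and "open" are said of these compounds alone.

Compound 2 `O=C(/C=C\c1ccccc1F)N1N=C(c2ccncc2)OC1c1c[nH]c2ccccc12` is the starting point of this comparison. In an ADME assay on HeLa cells (Homo sapiens) for cytotoxicity, read by MTT assay, with a stated time of 72 h (on this read-out lower numbers stand for stronger inhibition of growth and higher numbers for weaker inhibition of growth), compound 2 gives > 30 ug/mL, which is a limit of the assay rather than a number. Among the compounds with values here, its one neighbour, compound 1 `O=C(/C=C\c1cccc([N+](=O)[O-])c1)N1N=C(c2ccncc2)OC1c1c[nH]c2ccccc12`, also stands only at a limit: in this assay compound 1 gives > 30 ug/mL. The step that the two limits leave unreadable from compound 1 to compound 2 therefore cannot be sized, and the only pattern in the measured data is the limit of > 30 ug/mL in this assay, at which 2 of the 2 values shown sit.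

The next compound, compound 3 `O=C(/C=C\c1ccc(Cl)cc1)N1N=C(c2ccncc2)OC1c1c[nH]c2ccccc12`, differs from compound 2 in a single place: 4-chlorophenyl in place of 2-fluorophenyl on a double-bonded chain carbon bound to a double-bonded chain carbon. Within the data shown here, no measured step reads on this change, since the one step between the measured compounds is itself unreadable, and nothing in the data points to a move in either direction beyond the scatter. The expectation for compound 3 is thus that it, too, will sit at or near the limit, with an estimated step that the limit leaves unreadable from compound 2 to compound 3. The estimated value for compound 3 in this assay is 35 ug/mL, with a range from 15 ug/mL to 80 ug/mL.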

Compound 3, concentration for 50% growth inhibition: > 30 ug/mL
Compound 3 was reported as a limit; the forecaster's own chance of this, stated with the estimate: 70%; the middle value is on the limit's open side.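

In this assay compound 3 gives > 30 ug/mL as a limit of the assay and not a number. The steps linking compound 3 with compound 1 and compound 2 therefore cannot be read. The compounds shown leave open how far these three differ in growth inhibition, and whether any group at this place gives a value inside the limit.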